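Vero cytotoxicity notes: oxadiazoline series, hydroxyphenyl variant

The source may report more compounds than this note shows. Statements on the series, on what has been measured and on what is new or still open speak of the compounds shown alone.

Compound 1 `O=C(NNC(=O)c1ccccc1[N+](=O)[O-])c1ccc(-n2cccc2)cc1` gives 182000 nM in an ADME assay on Vero cells (Chlorocebus sabaeus) for cytotoxicity, read by MTT assay, with a stated time of 72 h; a higher number here means a weaker inhibitor, a lower number a stronger inhibitor. Compound 2 `CC(=O)N1N=C(c2ccc(-n3c(C)ccc3C)cc2)OC1c1ccccc1Cl` gives 201000 nM in this assay, a number that sits alongside that of compound 1 within the usual scatter, so no order between the two can be read. Compound 3 `Cc1ccc(C)n1-c1ccc(C(=O)N/N=C/c2ccccc2Cl)cc1` belongs to the same set, but in this assay compound 3 is recorded as "not determined" (no result reported), so it has no result here. No change between measured compounds can therefore be sized from these data.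

Compound 4 `CC(=O)N1N=C(c2ccc(-n3c(C)ccc3C)cc2)OC1c1ccc(O)cc1` differs from compound 2 in one place: 4-hydroxyphenyl in place of 2-chlorophenyl on a saturated ring carbon. Both measured compounds show only weak cytotoxicity, and the exchange of one six-membered aromatic ring of carbon only for another of the same size gives no basis for expecting a departure from that level. The step from compound 2 to compound 4 in this assay is expected to be small, a 1.1-fold higher number from compound 2 to compound 4 (0.04 log units; within the scatter), not beyond the scatter in either direction. Compound 4 is accordingly estimated at 220000 nM in this assay, with a range from 100000 nM to 480000 nM.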

Compound 4, half-maximal inhibitory concentration: 187000 nM
Estimate against measurement, compound 4: 1.2-fold (0.07 log units) above, within the range that was stated.
By their numbers in this assay, from the lowest: compounds 1, 4 and 2 (each within the scatter of the next).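

Within the data shown here, this gives the first readable step at the saturated ring carbon: in this assay, 4-hydroxyphenyl in place of 2-chlorophenyl gives a 1.1-fold lower number from compound 2 to compound 4 (0.03 log units; within the scatter). In this one pair, a ring carrying one hydrogen-bond donor and one hydrogen-bond acceptor and a ring carrying neither cannot be told apart in this assay. The exchange alters both the ring substituent and its place on the ring, and this single step does not separate those two parts; no measurement shown accounts for the result.

On these data alone, whether the same level holds with a carboxylic acid or an amine on that aromatic ring remains open. Also open, as far as these compounds go, is the outcome with a longer alkyl chain in place of the ring on that carbon.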